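The compounds below may be only part of what the source reports. "The series", "measured", "known", "first", "only" and "open" are said of these compounds alone.

Compound 2 (`CNCc1c(OC)cc(Oc2cccc(Nc3ccccc3)c2)cc1OC`) is the starting point of this step. In a functional assay on DLD-1 cells (Homo sapiens) for inhibition, read by MTT assay, with a stated time of 72 h (on this read-out lower numbers stand for stronger inhibition and higher numbers for weaker inhibition), compound 2 gives 11900 nM. Compound 3 (`COc1cc(Oc2cccc(Nc3ccccc3)c2)cc(OC)c1CNCCNC(C)=O`) gives 6010 nM, which lies within the scatter of the number for compound 2. Compound 1 (`COc1ccc(CCCNCc2c(OC)cc(Oc3ccc(Nc4ccccc4)cc3)cc2OC)cc1`) gives 4650 nM, and the gap between that number and the higher one for compound 2 lies beyond the scatter.

The next compound to be measured is compound 4 (`COc1cc(Oc2cccc(Nc3ccccc3)c2)cc(OC)c1CNC(C)C`). It differs from compound 2 by isopropyl in place of methyl on an amine nitrogen. Among the compounds with values here, one measured step bears directly on this change, as it also alters the group carried by that nitrogen: a 2.0-fold lower number from compound 2 to compound 3 (0.30 log units; within the scatter). Compound 1 has another group on the amine nitrogen too, but its core differs as well, so it offers no clean comparison. Given that the single step, a 2.0-fold lower number from compound 2 to compound 3 (0.30 log units; within the scatter), stays within the scatter, the change to compound 4 is expected to move the number little, if anything slightly downward. The estimate amounts to a 1.5-fold lower number from compound 2 to compound 4 (0.17 log units; within the scatter), an expected shift that stays within the scatter. For compound 4 the estimated value in this assay is 8000 nM, with an expected range from 3500 nM to 16000 nM.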

Compound 4, half-maximal inhibitory concentration: > 20000 nM
Compound 4: only a limit was reported (the forecaster's own chance of this, stated with the estimate: 3%); middle value at least 2.5-fold (0.39 log units) from the limit.
By their numbers in this assay, from the lowest: compounds 1, 3 and 2 (each within the scatter of the next, the first and the last beyond it). At a limit, above all of these: compound 4.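

In this assay compound 4 gives only a limit, > 20000 nM, and not a number. Its step from the methyl group, an at least 1.6-fold higher number from compound 2 to compound 4 (0.22 log units; that floor lies within the scatter), has a floor that lies within the scatter, so the limit alone does not settle how much isopropyl in place of methyl on an amine nitrogen changes the read-out. The comparison with the other chain is clearer: the earlier step, a 2.0-fold lower number from compound 2 to compound 3 (0.30 log units; within the scatter), stayed within the scatter, whereas an at least 3.3-fold higher number from compound 3 to compound 4 (0.52 log units; beyond the scatter) lies beyond it, which gives the first clean sign among these compounds with the shared core that the group on this nitrogen can separate two values, here isopropyl and 2-acetamidoethyl.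

As far as these compounds go, the true position of compound 4 beyond its limit remains open, and with it the real size of both new steps. Also open, from the compounds shown here alone, is whether an ethyl or cyclopropyl group on this nitrogen would give a number close to that of the methyl compound or would reach the same limit as isopropyl.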